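The compounds below may be only part of what the source reports. "The series", "measured", "known", "first", "only" and "open" are said of these compounds alone.

Of the compounds shown here, three have been measured in an assay on CHO cells for displacement of a labelled ligand from adenosine receptor A1 (Homo sapiens), read by scintillation counting, with a stated time of 60 min, tested at 10 uM; on this read-out lower numbers stand for less inhibition and higher numbers for more inhibition at the one concentration tested (going by the name of the read-out). Compound 3, `COc1cccc2cc(C(=O)NC3CCCCC3)c(=N)oc12`, gives 40% in this assay. Compound 2, `CCC(CO)NC(=O)c1cc2cccc(OC)c2oc1=N`, gives 24%. Compound 1, `N=c1oc2ccc(Br)cc2cc1C(=O)NC1CCCCC1`, gives 5%, the lowest of the three. The core of compound 1 and the core of compound 3 are not the same, and the difference between the two cores is not broken down here.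

Compound 2 and compound 3 share one core and differ in a single place: 1-(hydroxymethyl)propyl in place of cyclohexyl on an amide-type nitrogen. That change made a step of a number 16 percentage points lower from compound 3 to compound 2 (beyond the scatter).

Compound 4, `CCC(CO)NC(=O)c1cc2cc(Br)ccc2oc1=N`, has not yet been measured in this assay. It stands to compound 1 as compound 2 stands to compound 3, since the difference is 1-(hydroxymethyl)propyl in place of cyclohexyl on an amide-type nitrogen, the same change at the same kind of place.

Because compound 1 already sits at 5%, there is little room for a further fall, so the step from compound 1 to compound 4 is expected to be smaller than the earlier one, around a number 2 percentage points lower from compound 1 to compound 4 (within the scatter). For compound 4 the estimated value in this assay is 3%, expected to fall between -10% and 18%.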

Compound 4, a percentage reported as inhibition, at one concentration (the size of the read-out at that concentration, not a potency): 20%
Compound 4: the middle estimate sits 17 percentage points below what was measured, and the stated range ends below it.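

In this assay, putting 1-(hydroxymethyl)propyl in place of cyclohexyl on the amide-type nitrogen of the core of compound 1 gave a number 15 percentage points higher from compound 1 to compound 4 (beyond the scatter), so the fall seen on the other core did not recur. The same change therefore moved the read-out in opposite directions on the two cores, and its effect in this series cannot simply be carried from one core to the other: the same change on two cores in this assay, a number 16 percentage points lower (beyond the scatter) from compound 3 to compound 2 and a number 15 percentage points higher (beyond the scatter) from compound 1 to compound 4, 31 percentage points apart, beyond the scatter of two such steps. This rests on just two pairs of compounds, each read at one concentration, so it does not show which difference between the cores matters or which direction a third core would take.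

The compounds shown leave open how each core responds to other groups on the amide-type nitrogen, such as a longer carbon chain, an amine or a carboxylic acid. They also leave open whether the opposite steps would persist if the hydroxyl of 1-(hydroxymethyl)propyl were replaced by a methoxy group.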